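Swapping a cyclopentylmethyl amide for a trifluoromethylphenyl amide

A few compounds are considered here, and "the series" means these few. Any claim that something is new, unique, unknown or untested is made for them only; others in the source may bear on it.

Compound 1 `CCc1ccc(NC(=O)N2CCCN(C(=O)CCC3CCCC3)CC2)cc1`: 0.0833 h
Compound 2 `CC(C)(C)c1ccc(NC(=O)N2CCCN(C(=O)CC3CCCC3)CC2)cc1`: 0.05 h

In an in vitro ADME assay on microsomes from liver (Homo sapiens) for metabolic stability, read by LC-MS (a lower number here means that the compound disappears faster, a higher number that the compound lasts longer), compound 2 gives 0.05 h and compound 1 gives 0.0833 h; the two numbers lie within the usual scatter of each other, so they cannot be told apart. Compound 3 `CC(C)(C)c1ccc(NC(=O)N2CCCN(C(=O)c3ccc(C(F)(F)F)cc3)CC2)cc1` carries 4-(trifluoromethyl)phenyl in place of cyclopentylmethyl on a carbonyl carbon. Among the compounds with values here, no measured pair here shows what such a change does, so only an expectation is possible. Compound 3 is expected to last somewhat longer, a step of a 2.4-fold higher number from compound 2 to compound 3 (0.38 log units; beyond the scatter) in this assay, though perhaps not beyond the scatter. Compound 3 is estimated at 0.12 h, within 0.04 h to 0.4 h.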

Compound 3, half-life: 0.0667 h
Compound 3: the middle estimate sits 1.8-fold (0.26 log units) above what was measured; the measured number falls inside the stated range.
By their numbers in this assay, from the lowest: compounds 2, 3 and 1 (each within the scatter of the next).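

In this assay, putting 4-(trifluoromethyl)phenyl in place of cyclopentylmethyl on the carbonyl carbon gives a 1.3-fold higher number from compound 2 to compound 3 (0.13 log units; within the scatter). Within the data shown here, this is the first pair here that differs in one place, and at this position it shows no change that can be told apart from the scatter, even though a non-aromatic ring gives way to an aromatic one. No measurement available here accounts for this result. Still open is whether an amine or a carboxylic acid on this carbonyl carbon would give a half-life beyond the scatter of these compounds.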